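Moving the chlorine on the benzoyl ring of compound 3

A few compounds are considered here, and "the series" means these few. Any claim that something is new, unique, unknown or untested is made for them only; others in the source may bear on it.

Measured compounds:
- compound 1 `O=C(Nc1ccccc1C(F)(F)F)C1CCc2ccccc2N1C(=O)c1cccc(Cl)c1`: 526 nM
- compound 2 `CCCCCCCCC(=O)N1c2ccccc2CCC1C(=O)Nc1ccccc1O`: 65000 nM
- compound 3 `O=C(Nc1ccccc1O)C1CCc2ccccc2N1C(=O)c1ccccc1Cl`: 44200 nM

In a functional assay on ACHN cells (Homo sapiens) for cytotoxicity, read by sulforhodamine B assay, with a stated time of 72 h (on this read-out lower numbers stand for stronger inhibition of growth and higher numbers for weaker inhibition of growth), compound 3 stands second highest of the three, close to compound 2 and far from compound 1. Among the compounds with values here, the one measured step, a 1.5-fold lower number from compound 2 to compound 3 (0.17 log units; within the scatter), concerns a different part of the molecule and is within the scatter. Compound 4 `O=C(Nc1ccccc1O)C1CCc2ccccc2N1C(=O)c1cccc(Cl)c1` differs from compound 3 by 3-chlorophenyl in place of 2-chlorophenyl on a carbonyl carbon. Within the data shown here, no measured pair isolates this change; compound 1 carries the 3-chlorophenyl but also a different anilide, so its gap to compound 3 cannot be attributed to the chlorine position alone. The expected step of a 2.2-fold lower number from compound 3 to compound 4 (0.34 log units; beyond the scatter) is therefore small and uncertain, leaning toward a lower number. Compound 4 is estimated at 20000 nM, between 5000 nM and 60000 nM.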

Compound 4, concentration for 50% growth inhibition: 17200 nM
Compound 4: the middle estimate sits 1.2-fold (0.07 log units) above what was measured; the measured number falls inside the stated range.
By their numbers in this assay, from the lowest: compound 1; then compound 4; then compounds 3 and 2 (each within the scatter of the next).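

In this assay the chlorine's place on the ring matters: 3-chlorophenyl in place of 2-chlorophenyl gives a 2.6-fold lower number from compound 3 to compound 4 (0.41 log units; beyond the scatter) on an otherwise unchanged molecule, and 3-chlorophenyl in place of octyl gives a 3.8-fold lower number from compound 2 to compound 4 (0.58 log units; beyond the scatter) where 2-chlorophenyl gave only a 1.5-fold lower number from compound 2 to compound 3 (0.17 log units; within the scatter) within the scatter. Even so, hydroxy in place of trifluoromethyl gives a 33-fold higher number from compound 1 to compound 4 (1.51 log units; beyond the scatter) and so outweighs the chlorine shift in these compounds. Nothing available explains these steps. Still open, as far as these compounds go, is how 4-chlorophenyl would compare on this carbonyl carbon. Also open, from the compounds shown here alone, is what a methoxy or an amine would give in place of the hydroxy.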